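From 4-methylphenyl to 1,3-thiazol-2-yl in a sparse series

This account rests on a few compounds, and the source may have more. Where it says the series, first, only, none or still open, it means among the compounds named here.

Three compounds sharing one core have been taken into a functional assay on 1A9 cells (Homo sapiens) for cytotoxicity (a higher number here means that more compound is needed for the effect, a lower number that less compound is needed), so far. Going by the values given here, compound 1 (`COC1=C(C)C(=O)/C(=C(O)/C=C/c2ccccc2OC)C(=O)C1(C)C`) gives 2.5 ug/mL as the only number in the set. Compound 2 (`COC1=C(C)C(=O)/C(=C(O)/C=C/c2ccc(C)cc2)C(=O)C1(C)C`) stands at "not determined" (no result reported) and so has no place on the numeric scale. Compound 3 (`COC1=C(C)C(=O)/C(=C(O)/C=C/c2cccc3ccccc23)C(=O)C1(C)C`) is in the same position at "not determined" (no result reported) and offers no further reference.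

Compound 4 (`COC1=C(C)C(=O)/C(=C(O)/C=C/c2nccs2)C(=O)C1(C)C`) differs from compound 2 by one change (1,3-thiazol-2-yl in place of 4-methylphenyl on a double-bonded chain carbon bound to a double-bonded chain carbon). Without a number for compound 2, the size of this step in this assay cannot be read from the data and no direction can be assigned. The working assumption is no step beyond the usual scatter, which is an expectation and not a finding. Among the compounds with values here, the only anchor is compound 1 at 2.5 ug/mL for the estimate, so the range is kept wide. Compound 4 is expected at 3 ug/mL (estimated range 0.8 ug/mL to 10 ug/mL).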

Compound 4, concentration for half-maximal effect: 3.5 ug/mL
Compound 4: the middle estimate sits 1.2-fold (0.07 log units) below what was measured; low and high end bracket the measured number.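

In this assay the series now holds a 1.4-fold higher number from compound 1 to compound 4 (0.15 log units; within the scatter) as its first readable step, on a double-bonded chain carbon bound to a double-bonded chain carbon. Compounds with 2-methoxyphenyl and 1,3-thiazol-2-yl at this place cannot be told apart in this assay, so a five-membered aromatic ring with 2 hetero atoms and a six-membered aromatic ring of carbon only are both compatible with a result at this level. No supporting data that would explain this result are available.

Steps involving compound 2 and compound 3 cannot be read: neither compound has a number. Open too, going by these compounds, is whether a group of another kind at this place, such as an aminoalkyl chain, a carboxylic acid or a longer chain, would move the number beyond the scatter.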